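Chain-end amine swap in a T-type channel series

The source may hold more compounds than are shown below. What is called first, only, known or untested is meant among the compounds shown, and "the series" means these compounds.

Compound 1 `O=C(CC1c2ccccc2N=C(SCCCCCN2CCCC2)N1c1ccc(-c2ccc(F)cc2)cc1)NCc1ccccc1`: 2180 nM
Compound 2 `CN(C)CCCCCSC1=Nc2ccccc2C(CC(=O)NCc2ccccc2)N1c1ccccc1`: 18500 nM

In an assay on cells for inhibition of Voltage-dependent T-type calcium channel subunit alpha-1G (Homo sapiens), read by patch clamp (on this read-out higher numbers stand for weaker inhibition and lower numbers for stronger inhibition), compound 2 stands at the highest of the two numbers; compound 1 gives a lower number, and that gap lies beyond the scatter. Compound 1 differs from compound 2 in two places at once, so no single step can be read from the pair. Compound 3 `O=C(CC1c2ccccc2N=C(SCCCCCN2CCCC2)N1c1ccccc1)NCc1ccccc1` is not yet measured; it carries pyrrolidin-1-yl in place of dimethylamino on a saturated chain carbon, five bonds along the chain from a sulfur. Among the compounds with values here, with no counted step for this change alone, only a modest move toward lower numbers is expected, possibly still within the scatter, estimated as a 2.1-fold lower number from compound 2 to compound 3 (0.31 log units; beyond the scatter). Compound 3 is expected at 9000 nM, within 3000 nM to 25000 nM.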

Compound 3, half-maximal inhibitory concentration: 77000 nM
Compound 3: the middle estimate sits 8.6-fold (0.93 log units) below what was measured, outside the stated range (above it).
By their numbers in this assay, from the lowest: compound 1; then compound 2; then compound 3.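

In this assay pyrrolidin-1-yl in place of dimethylamino on a saturated chain carbon, five bonds along the chain from a sulfur, gives a 4.2-fold higher number from compound 2 to compound 3 (0.62 log units; beyond the scatter) in this pair, so this chain-end change alone moves the number away from the lower value of compound 1. Hydrogen in place of 4-fluorophenyl on an aromatic carbon gives a 35-fold higher number from compound 1 to compound 3 (1.55 log units; beyond the scatter) as the large step of the two, so the lower number of compound 1 goes with its 4-fluorophenyl group.

On these data alone, how a piperidin-1-yl chain end or a longer chain would read remains open. No supporting data explain either step.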